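Extending the pentyloxy chain of compound 3

The source may report more compounds than this note shows. Statements on the series, on what has been measured and on what is new or still open speak of the compounds shown alone.

Measured so far in a functional assay on brain (Rattus norvegicus, strain Wistar) for inhibition; on this read-out lower numbers stand for stronger inhibition and higher numbers for weaker inhibition:
compound 1 `CCCc1ccc(-c2c(C)[nH]c(=O)n2C)cc1` gives 21500 nM
compound 2 `Cc1[nH]c(=O)n(C)c1-c1ccc(C(C)(C)C)cc1` gives 8400 nM
compound 3 `CCCCCOc1ccc(-c2c(C)[nH]c(=O)n2C)cc1` gives 4500 nM

All three share one core and differ only in the group on its aromatic ring. One step, a 4.8-fold lower number from compound 1 to compound 3 (0.68 log units; beyond the scatter), is modest but beyond the scatter, with pentyloxy taking the place of propyl. Another, a 1.9-fold lower number from compound 2 to compound 3 (0.27 log units; within the scatter), stays within the scatter, with pentyloxy taking the place of tert-butyl. Compound 3 therefore shares the low end of these numbers with compound 2, and compound 1 stands apart from both.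

The next compound, compound 4 `CCCCCCCCCCOc1ccc(-c2c(C)[nH]c(=O)n2C)cc1`, lengthens the chain of compound 3, and the change is pentyl in place of hydrogen on a saturated chain carbon, five bonds along the chain from an oxygen on an aromatic ring in that chain. Within the data shown here, no measured step lengthens this chain directly, so the two steps above offer only indirect guidance. Both end at pentyloxy, and neither raises the number, so a modest further fall seems the likeliest outcome, though a change within the scatter would be no surprise. The expected change is a 2.5-fold lower number from compound 3 to compound 4 (0.40 log units; beyond the scatter) as a rough estimate. For compound 4 the estimated value is about 1800 nM in a range from 450 nM to 7000 nM as expected here.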

Compound 4, half-maximal inhibitory concentration: 6900 nM
Compound 4: middle estimate off by 3.8-fold (0.58 log units), on the low side; the measured number falls inside the stated range.
By their numbers in this assay, from the lowest: compounds 3, 4 and 2 (each within the scatter of the next); then compound 1.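

In this assay, adding pentyl on a saturated chain carbon, five bonds along the chain from an oxygen on an aromatic ring, gives a 1.5-fold higher number from compound 3 to compound 4 (0.19 log units; within the scatter), so this much extra chain can be added here without a difference that can be told from the scatter. Among these compounds, the earlier compounds swapped one group for another on an aromatic carbon, whereas this pair is the first to vary the length of the chain alone. The modest drop of a 4.8-fold lower number from compound 1 to compound 3 (0.68 log units; beyond the scatter), seen with pentyloxy in place of propyl, therefore finds no continuation in this longer chain. Nothing among the data shown explains this flat result.

The compounds shown leave open what happens with chains of intermediate length, such as hexyloxy or octyloxy, since only the two ends of this range appear here. They also leave open whether an amine or a carboxylic acid at the far end of the chain would move the number beyond the scatter in either direction.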